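A few compounds are considered here, and "the series" means these few. Any claim that something is new, unique, unknown or untested is made for them only; others in the source may bear on it.

In a functional assay on BXPC-3 cells (Homo sapiens) for cytotoxicity, read by fluorescence, with a stated time of 48 h (a higher number here means that more compound is needed for the effect, a lower number that less compound is needed), compound 1 `CC(C)=CCC/C(C)=C/CC/C(C)=C/CSC[C@H](NC(=O)CCCCCN1CCCC1)C(=O)NC1CCCCC1` gives 12700 nM as the higher of the two numbers measured, and compound 2 `CC(C)=CCC/C(C)=C/CC/C(C)=C/CSC[C@H](NC(=O)CCCCCN1CCCC1)C(=O)NC1CCCCCCC1` gives 4000 nM as the lower. Compound 3 `CC(C)=CCC/C(C)=C/CC/C(C)=C/CSC[C@H](NC(=O)CCCCCN1CCN(C)CC1)C(=O)NC1CCCCC1` differs from compound 1 by 4-methylpiperazin-1-yl in place of pyrrolidin-1-yl on a saturated chain carbon, five bonds along the chain from a carbonyl carbon and has not yet been measured. Among the compounds with values here, the only measured step of a 3.2-fold lower number from compound 1 to compound 2 (0.50 log units; beyond the scatter) replaces cyclohexyl with cyclooctyl on an amide-type nitrogen and not at this place, so it bears only weakly on the change, and no shift beyond the scatter is expected in this assay here. The estimated step is a 1.1-fold higher number from compound 1 to compound 3 (0.04 log units; within the scatter) and no more. Compound 3 is expected at 14000 nM within an estimated range from 5000 nM to 40000 nM at the two ends.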

Compound 3, half-maximal effective concentration: 12000 nM
Estimate against measurement, compound 3: 1.2-fold (0.07 log units) above, and the stated range covers the measured number.
By their numbers in this assay, from the lowest: compound 2; then compounds 3 and 1 (each within the scatter of the next).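

At the saturated chain carbon, five bonds along the chain from a carbonyl carbon, 4-methylpiperazin-1-yl in place of pyrrolidin-1-yl gives a 1.1-fold lower number from compound 1 to compound 3 (0.02 log units; within the scatter) in this assay, so this swap of ring groups makes no difference beyond the scatter. The earlier pair showed a change only on the amide-type nitrogen and gave no reading at this place. Nothing available here explains the result. Going by these compounds, whether a morpholin-4-yl group, a dimethylamino group or a longer chain at this place would read the same remains open, as does the outcome of pairing 4-methylpiperazin-1-yl with the cyclooctyl group of compound 2.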